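Removing the Methoxy From the Pendant Phenyl of Compound 2

The source may hold more compounds than are shown below. What is called first, only, known or untested is meant among the compounds shown, and "the series" means these compounds.

Compound 2 `COc1ccc(-c2[nH]c3ccc(OC)cc3c2/C=C(\C#N)S(=O)(=O)c2ccccc2)cc1` gives 508 nM in a functional assay on K562 cells (Homo sapiens) for inhibition, read by sulforhodamine B assay, with a stated time of 48 h (on this read-out lower numbers stand for stronger inhibition of growth and higher numbers for weaker inhibition of growth), the lowest of the three numbers at hand. Compound 1 `COc1ccc(-c2[nH]c3ccccc3c2/C=C(\C#N)S(=O)(=O)c2ccccc2)cc1` gives 535 nM in this assay, and the step of a 1.1-fold lower number from compound 1 to compound 2 (0.02 log units; within the scatter) shows that a methoxy in place of hydrogen on an aromatic carbon of the shared core leaves the number essentially unchanged. Compound 3 `O=C(/C(=C\c1c(-c2ccccc2)[nH]c2ccccc12)S(=O)(=O)c1ccccc1)c1ccccc1` gives 6500 nM in this assay; it differs from compound 2 in more than one place, so its weaker number cannot be tied to any single change.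

Compound 4 `COc1ccc2[nH]c(-c3ccccc3)c(/C=C(\C#N)S(=O)(=O)c3ccccc3)c2c1` differs from compound 2 by hydrogen in place of methoxy on an aromatic carbon, para to a large group, or, cut one bond further out, 4-methoxyphenyl to phenyl. For the measured compounds named here, no measured step isolates this change. Going by the values given here, the only single-place step, from compound 1 to compound 2, concerned a methoxy on the core and lay within the scatter, so it offers no direct guide. For compound 4 a small step toward a higher number, a 1.6-fold higher number from compound 2 to compound 4 (0.20 log units; within the scatter), is expected. Compound 4 is therefore estimated at 800 nM, with a range from 300 nM to 2500 nM.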

Compound 4, concentration for 50% growth inhibition: 1400 nM
Compound 4: middle estimate off by 1.8-fold (0.24 log units), on the low side; measured number inside the range.
By their numbers in this assay, from the lowest: compounds 2 and 1 (each within the scatter of the next); then compound 4; then compound 3.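

In this assay, going from 4-methoxyphenyl to phenyl gives a 2.8-fold higher number from compound 2 to compound 4 (0.44 log units; beyond the scatter), a modest step. For the compounds shown here, this is the first single-place change here to move the number beyond the scatter, whereas the methoxy added to the shared core gave a 1.1-fold lower number from compound 1 to compound 2 (0.02 log units; within the scatter) and stayed within it. So in this series the methoxy para to a large group counts for more than the one on the core, and nothing at hand explains the difference.

The compounds shown leave open whether a hydroxyl, an amine or a longer chain such as ethoxy on this carbon would keep the number near that of compound 2. They also leave open what phenyl in this place does when the core carries hydrogen instead of methoxy, as the core of compound 1 does.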